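A few compounds are considered here, and "the series" means these few. Any claim that something is new, unique, unknown or untested is made for them only; others in the source may bear on it.

Compound 1 `COc1cc(/C=C2\CN(C)C/C(=C\c3ccc(F)cc3)C2=O)cc(OC)c1` gives 21900 nM in an ADME assay on L02 cells (Homo sapiens) for cytotoxicity, read by MTT assay, with a stated time of 24 h; on this read-out higher numbers stand for weaker inhibition and lower numbers for stronger inhibition.
Compound 2 `COc1cc(/C=C2\CN(C)C/C(=C\c3ccc(Cl)cc3)C2=O)cc(OC)c1` gives 18900 nM.
Compound 3 `CN1C/C(=C\c2ccc(F)cc2)C(=O)/C(=C/c2ccc(C#N)cc2)C1` gives 20900 nM.

The change from compound 1 to compound 2 is chloro in place of fluoro on an aromatic carbon, and the step it made, a 1.2-fold lower number from compound 1 to compound 2 (0.06 log units; within the scatter), stays within the scatter of repeated measurements. Compound 3 rests on a different core from compound 1; how the two cores differ is not broken down here. Compound 4 `CN1C/C(=C\c2ccc(Cl)cc2)C(=O)/C(=C/c2ccc(C#N)cc2)C1` has not yet been measured. It differs from compound 3 by chloro in place of fluoro on an aromatic carbon, the same change as from compound 1 to compound 2, at a place described in the same words. A small step is expected here too because a 1.2-fold lower number from compound 1 to compound 2 (0.06 log units; within the scatter) was within the scatter. Compound 4 is therefore expected to give about 18000 nM in this assay, with a likely range from 9000 nM to 36000 nM. The expected step, a 1.2-fold lower number from compound 3 to compound 4 (0.06 log units; within the scatter), is estimated to remain within the scatter.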

Compound 4, half-maximal inhibitory concentration: 16200 nM
Compound 4: the middle estimate sits 1.1-fold (0.05 log units) above what was measured; the range from low to high includes it.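

In this assay, the change from 4-fluorophenyl to 4-chlorophenyl on the core of compound 3 gives a 1.3-fold lower number from compound 3 to compound 4 (0.11 log units; within the scatter), and it agrees with the step seen on the core of compound 1: the same change on two cores in this assay, a 1.2-fold lower number (0.06 log units; within the scatter) from compound 1 to compound 2 and a 1.3-fold lower number (0.11 log units; within the scatter) from compound 3 to compound 4, 1.1-fold (0.05 log units) apart, within the scatter of two such steps. On these two pairs, then, the change carries from one core to the other without a detectable difference between the steps. It does not show that chloro in place of fluoro shifts the number at all, since each step lies within the scatter, and two pairs cannot speak for other cores in the series.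

The compounds shown leave open how a bromo or a methoxy group would read at this same place on the aromatic ring. They also leave open whether an amine or a carboxylic acid in place of the nitrile would alter the step.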